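Benzyl for phenyl on the piperidine of compound 1

The source may hold more compounds than are shown below. What is called first, only, known or untested is meant among the compounds shown, and "the series" means these compounds.

Measured so far:
compound 1, `CC(=O)c1ccc(OCCCN2CCC(c3ccccc3)CC2)cc1O`: 19800 nM
compound 2, `CC(=O)c1ccc(OCCCCCCCCCN2CCN(Cc3ccccc3)CC2)cc1O`: 21600 nM

In an assay on isolated protein for inhibition of Amine oxidase [flavin-containing] B (Homo sapiens), read by fluorescence, with a stated time of 30 min (a higher number here means a weaker inhibitor, a lower number a stronger inhibitor), compound 1 gives 19800 nM, the lower of the two numbers, and compound 2 gives 21600 nM; the two lie within the scatter of each other, so no order between them is claimed. Compound 3, `CC(=O)c1ccc(OCCCN2CCC(Cc3ccccc3)CC2)cc1O`, differs from compound 1 by benzyl in place of phenyl on a saturated ring carbon. Among the compounds with values here, no pair differing in one place has been measured, so the size of this step is unknown. The change is expected to move this assay little, in no firm direction, and the step from compound 1 to compound 3 is estimated as a 1.2-fold lower number from compound 1 to compound 3 (0.09 log units; within the scatter). Compound 3 is expected at 16000 nM, within 5000 nM to 60000 nM.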

Compound 3, half-maximal inhibitory concentration: 18700 nM
For compound 3 the middle estimate is 1.2-fold (0.07 log units) below the measured one; measured number inside the range.
By their numbers in this assay, from the lowest: compounds 3, 1 and 2 (each within the scatter of the next).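

Within the data shown here, replacing phenyl with benzyl on the saturated ring carbon gives a 1.1-fold lower number from compound 1 to compound 3 (0.02 log units; within the scatter) in this assay, the first one-place comparison. Among these compounds, at this position, the change therefore produces no step that can be told from the scatter. Nothing available accounts for this result.

From the compounds shown here alone, whether phenethyl, a carboxylic acid or an amine at the same ring carbon would move the number remains open. So does the effect of a longer chain on the core of compound 3 with the benzyl group kept.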